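The source may report more compounds than this note shows. Statements on the series, on what has been measured and on what is new or still open speak of the compounds shown alone.

Compound 1 `CC(C)COC(=O)N1CCCc2cc(S(=O)(=O)N3CC(c4ccccc4)NC3=O)ccc21`: 2380 nM
Compound 2 `O=C1NC(c2ccccc2)CN1S(=O)(=O)c1ccc2c(c1)CCCN2C(=O)C(F)(F)F`: > 20000 nM
Compound 3 `NC(=O)N1CCCc2cc(S(=O)(=O)N3CC(c4ccccc4)NC3=O)ccc21`: not yet measured

In a functional assay on K562 cells (Homo sapiens) for antiproliferative activity, read by MTT assay (on this read-out higher numbers stand for weaker inhibition and lower numbers for stronger inhibition), compound 2 gives > 20000 nM, which is a limit and not a number. Compound 3 has amino in place of trifluoromethyl on a carbonyl carbon. Among the measured compounds shown here, one measured step bears on this position, an at least 8.4-fold higher number from compound 1 to compound 2 (0.92 log units; beyond the scatter), and it lies beyond the scatter. It involves isobutoxy rather than amino, so it gives only a loose guide. A partial return towards compound 1 is expected, which means an expected at least 2.5-fold lower number from compound 2 to compound 3 (0.39 log units; beyond the scatter) in this assay. For compound 3 the estimate is 8000 nM, with an expected range of 2500 nM to 20000 nM.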

Compound 3, half-maximal inhibitory concentration: 3660 nM
Compound 3: the middle estimate sits 2.2-fold (0.34 log units) above what was measured, within the range that was stated.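

With an at least 5.4-fold lower number from compound 2 to compound 3 (0.73 log units; beyond the scatter) in this assay amino on this carbonyl carbon brings back the activity missing with trifluoromethyl. With a 1.5-fold higher number from compound 1 to compound 3 (0.19 log units; within the scatter) amino and isobutoxy cannot be told apart here, so of the three groups only trifluoromethyl falls out. Going by these compounds, compound 2 stays a limit and not a number, so the full size of its loss remains unknown: the limit of > 20000 nM in this assay, at which 1 of the 3 values shown sits.

Open, on these data alone, is how a methylamino, a dimethylamino or a plain methyl on this carbonyl carbon would read. Also open, as far as these compounds go, is whether any group here goes beyond the level shared by compound 1 and compound 3.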